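This account rests on a few compounds, and the source may have more. Where it says the series, first, only, none or still open, it means among the compounds named here.

Compound 2 `CC(=O)c1cc(-c2ccc(F)cc2)cc2cc(-c3ccc(F)cc3)[nH]c12` is the lower of the two measured compounds in a functional assay on HeLa cells (Homo sapiens) for cytotoxicity, read by MTT assay, with a stated time of 2 days, tested at 100 uM; on this read-out lower numbers stand for a stronger effect and higher numbers for a weaker effect at the one concentration tested: compound 2 gives 9.31%, while compound 1 `CC(=O)c1cc(-c2ccccc2)cc2cc(-c3ccc(F)cc3)[nH]c12` gives 68.3%. For the measured compounds named here, the single measured step, a number 59 percentage points lower from compound 1 to compound 2 (beyond the scatter), shows that this aromatic carbon of the outer phenyl ring responds strongly to a substituent. Compound 3 `COc1ccc(-c2cc3cc(-c4ccc(F)cc4)cc(C(C)=O)c3[nH]2)cc1` differs from compound 2 by methoxy in place of fluoro on an aromatic carbon. Going by the values given here, no measured step covers an exchange of one substituent for another at this carbon, so the direction is open: the fluoro in compound 2 may or may not be what carries the low number. Compound 3 is therefore estimated at 40%, with a range from 8% to 80%. Among the compounds with values here, the expected step, a number 30.7 percentage points higher from compound 2 to compound 3 (beyond the scatter), is stated with low confidence because the only comparison, a number 59 percentage points lower from compound 1 to compound 2 (beyond the scatter), concerns a different substituent.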

Compound 3, a percentage reported as activity, at one concentration (the size of the read-out at that concentration, not a potency): 46.5%
Estimate against measurement, compound 3: 6.5 percentage points below, within the range that was stated.
By their numbers in this assay, from the lowest: compound 2; then compound 3; then compound 1.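

In this assay, the exchange gives a number 37.2 percentage points higher from compound 2 to compound 3 (beyond the scatter), so this carbon separates one substituent from another, not only a substituent from hydrogen, and the low number of compound 2 does not carry over to methoxy. Methoxy keeps only part of the drop seen with fluoro: compound 3 gives 46.5%, while the unsubstituted phenyl compound, compound 1, gives 68.3%. Nothing available accounts for the difference between these two groups.

With only hydrogen, fluoro and methoxy shown at this carbon, it remains open how a chlorine atom, an amine or a carboxylic acid would read here. On these data alone, it is also open whether the same order of groups would hold if the second 4-fluorophenyl group on the shared core were changed.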